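This account rests on a few compounds, and the source may have more. Where it says the series, first, only, none or still open, it means among the compounds named here.

Compound 3 `O=Cc1ccc(OCc2cn(-c3ccc(S(=O)(=O)N4CCc5ccccc5C4)cc3)nn2)cc1` carries a 4-formylphenyl group on an oxygen on a saturated carbon, attached to the shared core. In an ADME assay on Vero cells (Chlorocebus sabaeus) for cytotoxicity, with a stated time of 4 days (on this read-out lower numbers stand for stronger inhibition and higher numbers for weaker inhibition), compound 3 gives > 50 ug/mL, which is a limit of the assay rather than a measured number. Two close relatives have been tested in the same way. Compound 1 `Cc1ccccc1OCc1cn(-c2ccc(S(=O)(=O)N3CCc4ccccc4C3)cc2)nn1` gives in this assay a result of > 50 ug/mL, again a limit. Compound 2 `Cc1ccc(OCc2cn(-c3ccc(S(=O)(=O)N4CCc5ccccc5C4)cc3)nn2)cc1` gives in this assay a result of > 50 ug/mL, also a limit. The steps between these three, namely a step that the two limits leave unreadable from compound 1 to compound 2, a step that the two limits leave unreadable from compound 1 to compound 3 and a step that the two limits leave unreadable from compound 2 to compound 3, cannot be sized, because every one of the values sits at the limit of > 50 ug/mL in this assay, at which 3 of the 3 values shown sit. Compound 4 `O=S(=O)(c1ccc(-n2cc(COc3ccc4ccccc4c3)nn2)cc1)N1CCc2ccccc2C1` is the next member of this series, and it differs from compound 3 by naphthalen-2-yl in place of 4-formylphenyl on an oxygen on a saturated carbon. Going by the values given here, none of the measured steps gives a readable size, so no change in this part of the molecule has so far moved the read-out off the limit. Compound 4 is therefore expected to show a step of a number no higher from compound 3 to compound 4 (the limit leaves the size open) in this assay. On that basis compound 4 is estimated at 50 ug/mL in this assay, with a range from 20 ug/mL to 100 ug/mL, most likely reported again only as a limit.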

Compound 4, half-maximal inhibitory concentration: > 50 ug/mL
Compound 4: no number, only a limit; the forecaster's own chance of this, stated with the estimate: 85%; the middle value lies on the limit itself.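

Compound 4 gives only a limit in this assay, as do compound 1, compound 2 and compound 3, so none of its steps to those three compounds can be read: the limit of > 50 ug/mL in this assay, at which 4 of the 4 values shown sit. The compounds shown leave open what number any of these four would give, and whether any group in this place would give a measured number rather than a limit.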